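The source may hold more compounds than are shown below. What is called first, only, known or untested is meant among the compounds shown, and "the series" means these compounds.

Compounds measured in a functional assay on HepG2 cells (Homo sapiens) for inhibition, read by MTT assay, with a stated time of 72 h, tested at 30 uM (a lower number here means less inhibition of growth, a higher number more inhibition of growth at the concentration tested), so far:
compound 1 `C=CCc1ccc(OCc2cn(-c3ccc(OC)cc3)nn2)c(O)c1` gives 15.4%
compound 2 `C=CCc1ccc(OCc2cn(-c3ccccc3CO)nn2)c(O)c1` gives 4.2%

Compound 2 stands lowest of the two numbers; its nearest neighbour is compound 1 at a number 11.2 percentage points lower from compound 1 to compound 2 (beyond the scatter). Compound 3 `C=CCc1ccc(OCc2cn(-c3ccc(Br)cc3)nn2)c(O)c1` carries 4-bromophenyl in place of 2-(hydroxymethyl)phenyl on an aromatic nitrogen. Among the measured compounds shown here, the only step that bears on this position is a number 11.2 percentage points lower from compound 1 to compound 2 (beyond the scatter), a modest change on swapping the group on the aromatic nitrogen. With a group entering that again has no hydrogen-bond donor or acceptor, a modest rise is expected for compound 3, estimated at a number 9.8 percentage points higher from compound 2 to compound 3 (within the scatter). Compound 3 is expected to give 14%, with a range of 2% to 30%.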

Compound 3, percent growth inhibition at one concentration: 8.9%
Beside the measured number, compound 3's estimate is 5.1 percentage points above it; the measured number falls inside the stated range.
By their numbers in this assay, from the lowest: compounds 2, 3 and 1 (each within the scatter of the next, the first and the last beyond it).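

In this assay, 4-bromophenyl in place of 2-(hydroxymethyl)phenyl on the aromatic nitrogen gives (a number 4.7 percentage points higher from compound 2 to compound 3 (within the scatter)), and bromo in place of methoxy on an aromatic carbon gives (a number 6.5 percentage points lower from compound 1 to compound 3 (within the scatter)). Compound 3 therefore separates from neither neighbour, so the new group adds no difference at this position that can be read beyond the scatter.

From the compounds shown here alone, whether an amine or a carboxylic acid on this phenyl ring would give a number beyond the scatter of these three remains open. No measured evidence accounts for any of these numbers.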